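Replacing Bromo with tert-Butyl in a Three-Compound Series

The source may report more compounds than this note shows. Statements on the series, on what has been measured and on what is new or still open speak of the compounds shown alone.

In a functional assay on HCT-116 cells (Homo sapiens) for inhibition, read by CCK-8 assay, with a stated time of 72 h, tested at 2 uM (on this read-out higher numbers stand for more inhibition of growth at the one concentration tested and lower numbers for less inhibition of growth), three compounds with a shared core differ in one group. Compound 1 (`COc1ccc(SCc2ccc(C(=O)Nc3ccccc3N)cc2)cc1`) gives 73.3% and compound 2 (`CCc1ccc(SCc2ccc(C(=O)Nc3ccccc3N)cc2)cc1`) gives 40.7% on this measure. Compound 3 (`Nc1ccccc1NC(=O)c1ccc(CSc2ccc(Br)cc2)cc1`) gives 9.96% and stands lowest of the three. Compound 4 (`CC(C)(C)c1ccc(SCc2ccc(C(=O)Nc3ccccc3N)cc2)cc1`) alters one group of compound 3 (tert-butyl in place of bromo on an aromatic carbon). The most relevant step is a number 30.7 percentage points lower from compound 2 to compound 3 (beyond the scatter) since ethyl, like tert-butyl, contains only carbon and hydrogen. The step of a number 63.3 percentage points lower from compound 1 to compound 3 (beyond the scatter) shows how far a change at this place has moved the number. Within the data shown here, a clear rise, smaller than either step, is therefore expected in this assay with no tert-butyl compound yet measured. The expected step (a number 22 percentage points higher from compound 3 to compound 4 (beyond the scatter)) would place compound 4 between the bromo and methoxy compounds. The estimate for compound 4 is 32% (expected range 10% to 60%).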

Compound 4, percent growth inhibition at one concentration: 4.81%
Beside the measured number, compound 4's estimate is 27.2 percentage points above it; the measured number lies below the stated range.
By their numbers in this assay, from the lowest: compounds 4 and 3 (each within the scatter of the next); then compound 2; then compound 1.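

In this assay, having only carbon and hydrogen does not by itself hold the number up at this position: tert-butyl in place of ethyl gives a number 35.9 percentage points lower from compound 2 to compound 4 (beyond the scatter). Tert-butyl in place of bromo gives a number 5.2 percentage points lower from compound 3 to compound 4 (within the scatter), so these two unlike groups cannot be told apart here, while tert-butyl in place of methoxy gives a number 68.5 percentage points lower from compound 1 to compound 4 (beyond the scatter). Nothing available explains these steps.

Still open, going by these compounds, is whether an ethoxy group or an amine at this place would reach the number of methoxy.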